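The compounds below may be only part of what the source reports. "The series", "measured", "known", "first", "only" and "open" are said of these compounds alone.

The shared core runs through four compounds that differ only in the aromatic group attached to one carbon of that core. Compound 1 `Cn1cc(-c2cnc(NCc3c(F)ccc4c3CCO4)c3cn[nH]c(=O)c23)cn1`, compound 2 `CNC(=O)c1cc(-c2cnc(NCc3c(F)ccc4c3CCO4)c3cn[nH]c(=O)c23)n(C)n1`, compound 3 `Cc1nc(CO)ccc1-c1cnc(NCc2c(F)ccc3c2CCO3)c2cn[nH]c(=O)c12` and the still unmeasured compound 4 `Cc1ncccc1-c1cnc(NCc2c(F)ccc3c2CCO3)c2cn[nH]c(=O)c12` keep everything else the same. In an ADME assay on microsomes from liver (Homo sapiens) for metabolic stability, read by LC-MS, using NADPH, with stated times of 5 min and 30 min, tested at 1 uM (on this read-out higher numbers stand for fast clearance and lower numbers for slow clearance), compound 1 gives 21 mL.min-1.g-1. In this assay compound 2 reaches only < 3 mL.min-1.g-1, which is a limit of the assay rather than a number. In this assay compound 3 gives 11 mL.min-1.g-1, and of the two actual numbers shown, compound 1 is its nearest neighbour, the gap between them lying within the usual scatter, so no order can be read between those two. The change from compound 3 to compound 4 is hydrogen in place of hydroxymethyl on an aromatic carbon. Among the measured compounds shown here, no measured step removes a hydroxymethyl on its own; the nearest comparisons exchange the whole aromatic group, as in a 1.9-fold lower number from compound 1 to compound 3 (0.28 log units; within the scatter) and an at least 3.6-fold higher number from compound 2 to compound 3 (0.56 log units; beyond the scatter), which show that such exchanges can either stay within the scatter or move beyond it. Compound 4 is therefore expected to give 18 mL.min-1.g-1 in this assay, with a likely range from 7 mL.min-1.g-1 to 45 mL.min-1.g-1. The expected step is a 1.6-fold higher number from compound 3 to compound 4 (0.21 log units; within the scatter), a small rise that may well remain within the scatter.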

Compound 4, intrinsic clearance in microsomes in the Homo sapiens assay: 41 mL.min-1.g-1
For compound 4 the middle estimate is 2.3-fold (0.36 log units) below the measured one; measured number inside the range.
By their numbers in the Homo sapiens assay, from the lowest: compounds 3, 1 and 4 (each within the scatter of the next, the first and the last beyond it). At a limit, below all of these: compound 2.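

Taking the hydroxymethyl away on its own, from the aromatic carbon next to the ring nitrogen, is a single-group change at this position, and in the Homo sapiens assay it gives a 3.7-fold higher number from compound 3 to compound 4 (0.57 log units; beyond the scatter), while the exchange of one whole aromatic group for another gives a 2.0-fold higher number from compound 1 to compound 4 (0.29 log units; within the scatter). In the Homo sapiens assay the widest gap is an at least 13-fold higher number from compound 2 to compound 4 (1.13 log units; beyond the scatter), and the figure for compound 2 here is a limit of the assay, not a number. In a physicochemical assay for solubility, read by LC-MS, in phosphate buffer, with a stated time of 24 h, at pH 7.4 (on this read-out higher numbers stand for higher solubility and lower numbers for lower solubility), compound 3 gives 3000 nM.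

In the physicochemical assay compound 4 gives < 2000 nM, a limit of the assay and not a number, so the size of the step between these two compounds in solubility cannot be read. Also open, as far as these compounds go, is whether another group at this same place, such as an amine, a methoxy or a carboxylic acid, would keep the lower clearance number of compound 3, and whether adding a hydroxymethyl would shift the number in the same way on a different aromatic group.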